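Lengthening the chain at the hydrazone carbon of compound 1

A few compounds are considered here, and "the series" means these few. Any claim that something is new, unique, unknown or untested is made for them only; others in the source may bear on it.

Measured compounds in a functional assay on HT-29 cells (Homo sapiens) for antiproliferative activity, read by sulforhodamine B assay; a lower number here means a stronger inhibitor, a higher number a weaker inhibitor:
compound 1, `CC/C(=N\Nc1nc2ccccc2o1)c1ccccn1`, gives 409 nM
compound 2, `C/C(=N\Nc1nc2ccccc2o1)c1ccc(C)nn1`, gives 6770 nM
compound 3, `C/C(=N\Nc1nc2ccccc2o1)c1ccc2ccccc2n1`, gives 7760 nM

Among these three, compound 1 has the lowest number and is therefore the strongest inhibitor of the set, with a gap to compound 2 and to compound 3 that lies beyond the scatter in each case. Among the measured compounds shown here, no pair of the measured compounds differs in just one place, so their values show only that compound 1 stands clearly apart.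

Compound 4, `CCC/C(=N\Nc1nc2ccccc2o1)c1ccccn1`, is the one not yet measured. It differs from compound 1 in a single spot: methyl in place of hydrogen on a saturated chain carbon, two bonds along the chain from a carbon with a double bond to nitrogen. Read one bond further out, the change is from ethyl to propyl on the chain that hangs from the carbon double-bonded to nitrogen. For the measured compounds named here, nothing among the measured compounds tracks such a change in isolation.

The expectation is a small step in this assay, if any, with compound 4 near compound 1 and perhaps a little weaker. The estimated step of a 1.3-fold higher number from compound 1 to compound 4 (0.13 log units; within the scatter) stays within the usual scatter. Compound 4 is expected to give about 550 nM, with a likely range from 200 nM to 1600 nM.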

Compound 4, half-maximal inhibitory concentration: 851 nM
Beside the measured number, compound 4's estimate is 1.5-fold (0.19 log units) below it, within the range that was stated.
By their numbers in this assay, from the lowest: compound 1; then compound 4; then compounds 2 and 3 (each within the scatter of the next).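

Among the compounds shown here, this is the first pair in the set that differs in one place only, so the chain on the carbon double-bonded to nitrogen can now be judged on its own. In this assay, changing ethyl to propyl gives a 2.1-fold higher number from compound 1 to compound 4 (0.32 log units; beyond the scatter) and so costs a modest amount of potency, which shows that this position responds to the addition of a single methyl. Nothing here explains why this step goes in this direction.

A single step cannot show whether a still longer chain such as butyl would move the number further in the same direction, or whether a branched isopropyl or a chain ending in an amine would behave differently. As far as these compounds go, how a plain methyl at this place on the core of compound 1 would compare also remains open.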